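A few compounds are considered here, and "the series" means these few. Any claim that something is new, unique, unknown or untested is made for them only; others in the source may bear on it.

In a functional assay on NCI-H460 cells (Homo sapiens) for cytotoxicity, read by sulforhodamine B assay, with a stated time of 3 days (on this read-out lower numbers stand for stronger inhibition and higher numbers for weaker inhibition), compound 1 `OCc1cn(Cc2ccc(Cl)cc2)c2ccccc12` gives 16 nM. Compound 2 `OCc1cn(Cc2ccc(Cl)cc2)c2ccc(F)cc12` gives 30 nM, so these two sit together at the low end of the numbers. Compound 3 `COc1ccc2c(c1)c(CO)cn2Cc1ccc(Cl)cc1` stands well apart at 1510 nM. Compound 4 `OCCc1cn(Cc2ccc(Cl)cc2)c2ccccc12` keeps the core of compound 1 and changes only the side chain: hydroxymethyl in place of hydroxy on a saturated chain carbon bound to an aromatic carbon. The same difference reads as hydroxymethyl to 2-hydroxyethyl.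

Within the data shown here, no measured step touches this chain, so the evidence is indirect. All three measured steps are changes on an aromatic carbon. Fluoro gives a 1.9-fold higher number from compound 1 to compound 2 (0.27 log units; within the scatter), which is within the scatter, while methoxy gives a 94-fold higher number from compound 1 to compound 3 (1.97 log units; beyond the scatter), and replacing fluoro with methoxy gives a 50-fold higher number from compound 2 to compound 3 (1.70 log units; beyond the scatter). A single small change can therefore leave the number unmoved or shift it greatly, so the size of this step is uncertain. Since compound 1 already sits at the low end, a large move to a higher number, meaning weaker inhibition, is expected in this assay. The estimated step is a 50-fold higher number from compound 1 to compound 4 (1.70 log units; beyond the scatter). For compound 4 the estimated value is 800 nM, with an expected range from 60 nM to 10000 nM.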

Compound 4, half-maximal inhibitory concentration: > 31600 nM
Compound 4 was reported as a limit; the forecaster's own chance of this, stated with the estimate: 20%; middle value at least 39-fold (1.59 log units) from the limit.
By their numbers in this assay, from the lowest: compounds 1 and 2 (each within the scatter of the next); then compound 3. At a limit, above all of these: compound 4.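

The earlier compounds shown here changed only an aromatic carbon, and compound 4 shows that the side chain of the core of compound 1 also controls the result. In this assay, going from hydroxymethyl to 2-hydroxyethyl gives an at least 1900-fold higher number from compound 1 to compound 4 (3.29 log units; beyond the scatter), so this small extension weakens inhibition sharply, and further than methoxy does in a 94-fold higher number from compound 1 to compound 3 (1.97 log units; beyond the scatter). Compound 4 gives > 31600 nM, which is a limit of the assay and not a number: the limit of > 31600 nM in this assay, at which 1 of the 4 values shown sits.

With only these two chains in view, the data cannot say why the longer one does so much worse, or how the number changes with chain length. A longer chain such as 3-hydroxypropyl, or an amine or a carboxylic acid in place of the hydroxy, remains an open case at this position.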